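The source may hold more compounds than are shown below. What is called first, only, known or untested is meant among the compounds shown, and "the series" means these compounds.

The series is followed in an ADME assay on BJ cells (Homo sapiens), read by MTT assay, with a stated time of 72 h; a higher number here means a weaker inhibitor, a lower number a stronger inhibitor. Compound 1 `COc1ncnc2c1c(-c1ccsc1)cn2[C@@H]1O[C@H](CO)[C@@H](O)[C@H]1O` gives 64300 nM in this assay, and compound 2 `CN(C)c1ncnc2c1c(-c1ccoc1)cn2[C@@H]1O[C@H](CO)[C@@H](O)[C@H]1O` gives 99200 nM. Compound 3 `Cc1nc(N)c2c(-c3ccccc3)cn([C@@H]3O[C@H](CO)[C@@H](O)[C@H]3O)c2n1` returns only a limit in this assay, > 100000 nM, and that is the limit of > 100000 nM in this assay, at which 1 of the 3 values shown sits. Compound 3 thus stands at the limit of this assay, with no number of its own to set against compound 1 or compound 2. Compound 4 `Cc1nc(N)c2c(-c3ccco3)cn([C@@H]3O[C@H](CO)[C@@H](O)[C@H]3O)c2n1` is not yet measured. It differs from compound 3 in one place: furan-2-yl in place of phenyl on an aromatic carbon. Among the measured compounds shown here, no step between measured compounds covers this change. Since compound 3 reaches only the limit of this assay, and since compound 1 and compound 2, which also carry a five-membered aromatic ring with 1 hetero atom, sit near that limit, the step is expected to be small, none beyond the scatter, as a number no higher from compound 3 to compound 4 (the limit leaves the size open). Compound 4 is estimated at 100000 nM in this assay, with a range from 50000 nM to 200000 nM, and a fair chance that only a limit is reported again.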

Compound 4, half-maximal inhibitory concentration: > 100000 nM
Compound 4: a limit, no number (the forecaster's own chance of this, stated with the estimate: 55%); the middle value sits exactly at the limit.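

Compound 3 and compound 4 both return only a limit in this assay, so no step can be read for furan-2-yl in place of phenyl: the limit of > 100000 nM in this assay, at which 2 of the 4 values shown sit.

The compounds shown leave open whether this change shifts the value at all, and in which direction.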